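Trimming the chain on the ring amine nitrogen

The source may hold more compounds than are shown below. What is called first, only, known or untested is meant among the compounds shown, and "the series" means these compounds.

Among the compounds with values here, compound 3 `CCCCN1CCN(c2nc3ccccc3n2CCOCC)CC1` sits second highest of the three numbers so far in a functional assay on ileum for inhibition of histamine H1 receptor (Cavia porcellus) (a lower number here means a stronger inhibitor, a higher number a weaker inhibitor), where compound 3 gives 15 nM. Its nearest neighbour is compound 1 `CCOCCn1c(N2CCN(C)CC2)nc2ccccc21`, which gives 10 nM; the step of a 1.5-fold higher number from compound 1 to compound 3 (0.18 log units; within the scatter) lies within the scatter. Its furthest is compound 2 `CCCCCN1CCN(c2nc3ccccc3n2CCOCC)CC1`, which gives 30 nM; here too the step of a 2.0-fold lower number from compound 2 to compound 3 (0.30 log units; within the scatter) stays within the scatter. Within the data shown here, the only step beyond the scatter is a 3.0-fold higher number from compound 1 to compound 2 (0.48 log units; beyond the scatter).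

Compound 4 `CCOCCn1c(N2CCN(CC)CC2)nc2ccccc21` is yet to be measured. Its change from compound 3 reads: hydrogen in place of ethyl on a saturated chain carbon, two bonds along the chain from an amine nitrogen in a ring. Cut one bond further out, this is butyl to ethyl, so the chain on the amine nitrogen in a ring is brought toward what compound 1 carries without reaching it. Among the measured compounds shown here, the steps that bear on it are a 1.5-fold higher number from compound 1 to compound 3 (0.18 log units; within the scatter) and a 2.0-fold lower number from compound 2 to compound 3 (0.30 log units; within the scatter), both within the scatter, and the longer span a 3.0-fold higher number from compound 1 to compound 2 (0.48 log units; beyond the scatter), modest. A chain of intermediate length should therefore come out close to both compound 1 and compound 3, and no step beyond the scatter is expected for a 1.3-fold lower number from compound 3 to compound 4 (0.10 log units; within the scatter). Compound 4 is estimated at 12 nM, with a range from 6 nM to 24 nM.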

Compound 4, half-maximal inhibitory concentration: 18 nM
Compound 4: middle estimate off by 1.5-fold (0.18 log units), on the low side, within the range that was stated.
By their numbers in this assay, from the lowest: compounds 1, 3, 4 and 2 (each within the scatter of the next, the first and the last beyond it).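

Ethyl on the ring amine nitrogen sets compound 4 apart from none of its neighbours in this assay, as all three new steps stay within the scatter (a 1.2-fold higher number from compound 3 to compound 4 (0.08 log units; within the scatter)) and (a 1.7-fold lower number from compound 2 to compound 4 (0.22 log units; within the scatter)) and (a 1.8-fold higher number from compound 1 to compound 4 (0.26 log units; within the scatter)), so the one span beyond the scatter, from the chain of compound 1 to the chain of compound 2, now breaks into smaller steps. Lengthening the chain by the same amount reads alike from two starting chains: the same change on two cores in this assay, a 1.5-fold higher number (0.18 log units; within the scatter) from compound 1 to compound 3 and a 1.7-fold higher number (0.22 log units; within the scatter) from compound 4 to compound 2, 1.1-fold (0.05 log units) apart, within the scatter of two such steps.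
Shortening it reads alike as well: the same change on two cores in this assay, a 2.0-fold lower number (0.30 log units; within the scatter) from compound 2 to compound 3 and a 1.8-fold lower number (0.26 log units; within the scatter) from compound 4 to compound 1, 1.1-fold (0.05 log units) apart, within the scatter of two such steps.

Still open, from the compounds shown here alone, is how a benzyl group, a hydroxyethyl chain or a bare hydrogen on that nitrogen would read in this assay. Also open, going by these compounds, is whether a chain longer than that of compound 2 would move the number further.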